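The source may hold more compounds than are shown below. What is called first, only, known or untested is meant among the compounds shown, and "the series" means these compounds.

Measured compounds, with values in a functional assay on CEM-DNR-bulk cells (Homo sapiens), read by MTT assay, with a stated time of 72 h; on this read-out higher numbers stand for weaker inhibition and lower numbers for stronger inhibition:
Compound 1 `COc1nc(N)nc2c1c(-c1ccccc1)cn2[C@@H]1O[C@H](CO)[C@@H](O)[C@H]1O` gives > 20000 nM, a limit of the assay.
Compound 2 `COc1nc(N)nc2c1c(-c1cccs1)cn2[C@@H]1O[C@H](CO)[C@@H](O)[C@H]1O` gives > 20000 nM, a limit of the assay.
Compound 3 `C#Cc1cn([C@@H]2O[C@H](CO)[C@@H](O)[C@H]2O)c2nc(N)nc(OC)c12` gives > 20000 nM, a limit of the assay.

Compound 3 therefore stands at the limit, where all three measured compounds sit (the limit of > 20000 nM in this assay, at which 3 of the 3 values shown sit); nothing separates it from the other two. The measured steps bearing on substituent exchange at this aromatic carbon are a step that the two limits leave unreadable from compound 1 to compound 2, a step that the two limits leave unreadable from compound 1 to compound 3 and a step that the two limits leave unreadable from compound 2 to compound 3. None of them can be read, since both ends of each lie at the limit.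

Compound 4 `COc1nc(N)nc2c1c(-c1ccco1)cn2[C@@H]1O[C@H](CO)[C@@H](O)[C@H]1O` is the next member. It differs from compound 3 as follows: furan-2-yl in place of ethynyl on an aromatic carbon. The nearest measured counterpart, in which a five-membered aromatic ring with one hetero atom is set against ethynyl at the same carbon, is the step from compound 2 to compound 3, and that step is unreadable. For the measured compounds named here, no measured step gives a direction or a size, so no step beyond the scatter is expected in this assay.

The expected step is a number no higher from compound 3 to compound 4 (the limit leaves the size open). Compound 4 is expected to give 20000 nM, with a range from 8000 nM to 50000 nM, most likely reported again as a limit.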

Compound 4, half-maximal inhibitory concentration: > 20000 nM
Compound 4 ended at the assay's limit (the forecaster's own chance of this, stated with the estimate: 80%); the middle value lies on the limit itself.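

For the compounds shown here, no step from compound 1, compound 2 or compound 3 to compound 4 can be read, since both ends of each lie at the limit: the limit of > 20000 nM in this assay, at which 4 of the 4 values shown sit. The compounds shown leave open whether phenyl, thiophen-2-yl, ethynyl and furan-2-yl differ at all in inhibition.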